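Amine swap on the shared core, compound 3 to compound 4

The source may report more compounds than this note shows. Statements on the series, on what has been measured and on what is new or still open speak of the compounds shown alone.

Compound 1 `CCCNc1nc2ccccc2c(NCc2ccc(NC(=O)c3ccc(F)cc3)cc2)c1C#N` in a functional assay on HCT-116 cells (Homo sapiens) for inhibition, read by luminescence and resazurin assay, with a stated time of 3 days (a lower number here means a stronger inhibitor, a higher number a weaker inhibitor), gives only a limit, > 20000 nM. Compound 2 `CCNc1nc(NCc2ccc(NC(=O)c3ccc(F)cc3)cc2)c2ccccc2n1` gives 1400 nM. Compound 3 `CCNc1nc(NCc2ccc(C(=O)Nc3ccc(F)cc3)cc2)c2ccccc2n1` gives 1900 nM. Going by the values given here, the single measured step, a 1.4-fold higher number from compound 2 to compound 3 (0.13 log units; within the scatter), turns the amide round and leaves the number essentially unchanged. Compound 3 therefore stands as the higher of the two numbers, with compound 2 its nearest neighbour and inside the scatter of it, while compound 1 sits at the limit of > 20000 nM in this assay, at which 1 of the 3 values shown sits, and adds no number.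

Compound 4 `CC1CN(c2nc(NCc3ccc(C(=O)Nc4ccc(F)cc4)cc3)c3ccccc3n2)CCN1` differs from compound 3 by 3-methylpiperazin-1-yl in place of ethylamino on an aromatic carbon, on an aromatic carbon between two ring nitrogen atoms of the shared core. Among the compounds with values here, no measured step touches this position; the only step available concerns the amide and was within the scatter, so it gives no direction for the present change. With nothing to anchor a shift, the expected step of a 1.3-fold lower number from compound 3 to compound 4 (0.10 log units; within the scatter) is set near zero, and the range is left wide to cover a real move either way. Compound 4 is accordingly estimated at 1500 nM in this assay, with a range from 300 nM to 8000 nM.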

Compound 4, half-maximal inhibitory concentration: 2800 nM
The estimate for compound 4 lay 1.9-fold (0.27 log units) below the measured number; measured number inside the range.
By their numbers in this assay, from the lowest: compounds 2, 3 and 4 (each within the scatter of the next). At a limit, above all of these: compound 1.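

The aromatic carbon between two ring nitrogen atoms now has its first measured step. In this assay, replacing ethylamino with 3-methylpiperazin-1-yl gives a 1.5-fold higher number from compound 3 to compound 4 (0.17 log units; within the scatter). For this one pair, then, an open chain of 3 heavy atoms and a six-membered non-aromatic ring of 7 heavy atoms, carrying one more hydrogen-bond acceptor, give numbers within the scatter of each other, so the larger ring-bearing group leaves the reading in this assay where it was. The data shown offer no measured property that would explain this step or account for the two groups reading alike.

On these data alone, it remains open whether this holds for other groups at the same position, such as an unsubstituted piperazine, a morpholine ring, a dimethylamino group or a longer chain such as butylamino, and whether the methyl group on the ring matters at all. Going by these compounds alone, also open is whether 3-methylpiperazin-1-yl behaves the same way with the amide turned round, as in compound 2, since the single pair here carries only the amide orientation of compound 3.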